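Methoxymethyl for Phenoxy on the Biaryl Terminus

This account rests on a few compounds, and the source may have more. Where it says the series, first, only, none or still open, it means among the compounds named here.

Measured compounds:
Compound 1: `CC[C@H](C)[C@H](N)CN(C(=O)[C@@H]1C[C@H]1c1ccccc1)c1ccc(-c2ccc(OC)cc2)cc1` with 120 nM
Compound 2: `CC[C@H](C)[C@H](N)CN(C(=O)[C@@H]1C[C@H]1c1ccccc1)c1ccc(-c2ccc(Oc3ccccc3)cc2)cc1` with 94 nM

Within the data shown here, compound 2 carries the phenoxy terminus and gives 94 nM in a functional assay for agonist activity at G protein-coupled receptor 88 (Homo sapiens), read by HTRF and cAMP accumulation (a lower number here means that less compound is needed, a higher number that more compound is needed for the effect), the lowest of the two numbers so far; its nearest neighbour, compound 1, is within the scatter of it, so the two cannot be ranked. Among the measured compounds shown here, the only measured step, a 1.3-fold lower number from compound 1 to compound 2 (0.11 log units; within the scatter), exchanges methyl for phenyl on the oxygen and changes nothing beyond the scatter.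

Compound 3, `CC[C@H](C)[C@H](N)CN(C(=O)[C@@H]1C[C@H]1c1ccccc1)c1ccc(-c2ccc(COC)cc2)cc1`, is obtained from compound 2 by the change (methoxymethyl in place of phenoxy on an aromatic carbon), on an aromatic carbon of a six-membered aromatic ring of carbon only. This shrinks the terminus back to a size close to that of compound 1, with the oxygen now one carbon further from the ring. For the measured compounds named here, the single measured step bears on it only loosely: because a 1.3-fold lower number from compound 1 to compound 2 (0.11 log units; within the scatter) is within the scatter, the terminus at this position appears tolerant of both a small and a large group, and no step beyond the scatter is expected for this assay here either.

Compound 3 is therefore estimated at 130 nM (range 50 nM to 400 nM), a step of a 1.4-fold higher number from compound 2 to compound 3 (0.14 log units; within the scatter) that is expected to stay within the scatter.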

Compound 3, half-maximal effective concentration: 35 nM
Compound 3: middle estimate off by 3.7-fold (0.57 log units), on the high side; measured number below the stated range.
By their numbers in this assay, from the lowest: compound 3; then compounds 2 and 1 (each within the scatter of the next).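

In this assay this position now separates its groups: the step to methoxymethyl from the phenoxy terminus (a 2.7-fold lower number from compound 2 to compound 3 (0.43 log units; beyond the scatter)) and the step to it from the methoxy terminus (a 3.4-fold lower number from compound 1 to compound 3 (0.54 log units; beyond the scatter)) both lie beyond the scatter, whereas the exchange of methyl for phenyl on the oxygen (a 1.3-fold lower number from compound 1 to compound 2 (0.11 log units; within the scatter)) did not. The terminus on this aromatic carbon is therefore not indifferent to the group it carries, and among these three compounds methoxymethyl stands apart from both methoxy and phenoxy, which remain within the scatter of each other. No accompanying measurement offers an explanation for these steps.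

The compounds shown leave open whether the oxygen of methoxymethyl is needed for the lower number, a question that an ethyl group at this place would address, and whether a longer chain such as ethoxymethyl keeps it. They also leave open whether a hydroxymethyl or an aminomethyl group on the same aromatic carbon would give a similar number on the shared core.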